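Swapping the aryl group on the shared core of compound 3

The source may report more compounds than this note shows. Statements on the series, on what has been measured and on what is new or still open speak of the compounds shown alone.

Of the compounds shown here, three have been tested so far in a functional assay on Ehrlich cells (Mus musculus) for cytotoxicity, tested at 25 ug/mL; a higher number here means a stronger effect of the compound at the concentration tested, a lower number a weaker effect. They share one core and differ only in the aryl group on a saturated ring carbon. Compound 1, `COc1cc(N2C(N)=C(C#N)C(c3ccccc3O)C3=C2CC(C)(C)CC3=O)cc(OC)c1OC`, carries a 2-hydroxyphenyl and gives 0% in this assay. Compound 2, `COc1cc(N2C(N)=C(C#N)C(c3ccc(Cl)cc3Cl)C3=C2CC(C)(C)CC3=O)cc(OC)c1OC`, carries a 2,4-dichlorophenyl and gives 55%. Compound 3, `COc1cc(N2C(N)=C(C#N)C(c3cccc([N+](=O)[O-])c3)C3=C2CC(C)(C)CC3=O)cc(OC)c1OC`, carries a 3-nitrophenyl and gives 20%, which places it second highest of the three: the change a number 20 percentage points higher from compound 1 to compound 3 (beyond the scatter), and a number 35 percentage points lower from compound 2 to compound 3 (beyond the scatter).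

Compound 4, `COc1ccccc1C1C(C#N)=C(N)N(c2cc(OC)c(OC)c(OC)c2)C2=C1C(=O)CC(C)(C)C2`, is not yet measured. It differs from compound 3 in one place: 2-methoxyphenyl in place of 3-nitrophenyl on a saturated ring carbon. Within the data shown here, the steps that bear on it are a number 55 percentage points higher from compound 1 to compound 2 (beyond the scatter) and a number 20 percentage points higher from compound 1 to compound 3 (beyond the scatter), both changes of the same aryl group; they show that this position moves the read-out by large amounts. Because compound 1 with 2-hydroxyphenyl gives 0% while compound 3 with 3-nitrophenyl gives 20%, a small drop is expected. Compound 4 is expected to give about 10%, between 0% and 35%. This estimate means an expected step of a number 10 percentage points lower from compound 3 to compound 4 (within the scatter).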

Compound 4, a percentage reported as activity, at one concentration (the size of the read-out at that concentration, not a potency): 65%
The estimate for compound 4 lay 55 percentage points below the measured number, outside the stated range (above it).
By their numbers in this assay, from the lowest: compound 1; then compound 3; then compounds 2 and 4 (each within the scatter of the next).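

At this position, a very small edit can change the read-out completely: in this assay, methyl in place of hydrogen on an oxygen on an aromatic ring gives a number 65 percentage points higher from compound 1 to compound 4 (beyond the scatter). The 2-methoxyphenyl group also separates clearly from the 3-nitrophenyl group, with a number 45 percentage points higher from compound 3 to compound 4 (beyond the scatter), while the change from the 2,4-dichlorophenyl group gives a number 10 percentage points higher from compound 2 to compound 4 (within the scatter), so two differently substituted aryl groups give matching read-outs here. No measurement at hand explains these steps.

From the compounds shown here alone, it remains open whether the methoxy group needs to stand where it does in the 2-methoxyphenyl group, which a 3-methoxyphenyl or 4-methoxyphenyl group would test. Going by these compounds, it is also open whether a longer chain on the same oxygen, such as ethyl or propyl, would keep the read-out at this level.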